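Swapping Phenyl for Dimethoxyphenyl in Compound 1

The source may hold more compounds than are shown below. What is called first, only, known or untested is meant among the compounds shown, and "the series" means these compounds.

Compound 1 `COc1cc(-c2nnc(SC)n2/N=C/c2ccccc2)cc(OC)c1OC` is tested in a functional assay on MKN-45 cells (Homo sapiens) for cytotoxicity, read by MTT assay, with a stated time of 48 h (a lower number here means a stronger inhibitor, a higher number a weaker inhibitor), where compound 1 gives 28500 nM. Among the compounds with values here, this is the only plain number in the set. Compound 2 `COc1cc(-c2nnc(SCc3ccccc3Cl)n2/N=C/c2ccccc2)cc(OC)c1OC` reaches only the limit of > 200000 nM in this assay. The step of an at least 7.0-fold higher number from compound 1 to compound 2 (0.84 log units; beyond the scatter) is at least modest, consistent with the limit of > 200000 nM in this assay, at which 1 of the 2 values shown sits. Compound 3 `COc1ccc(/C=N/n2c(SC)nnc2-c2cc(OC)c(OC)c(OC)c2)c(OC)c1` differs from compound 1 at a different place: 2,4-dimethoxyphenyl in place of phenyl on a carbon with a double bond to nitrogen. Within the data shown here, no measured step touches this part of the molecule, since the one measured step alters the group on a saturated chain carbon bound to a sulfur, so it offers no guide to size or direction here. Compound 3 is therefore expected to show a 1.1-fold higher number from compound 1 to compound 3 (0.02 log units; within the scatter), a step not clearly beyond the scatter. The estimate for compound 3 in this assay is 30000 nM, with a range from 10000 nM to 100000 nM.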

Compound 3, half-maximal inhibitory concentration: > 200000 nM
Compound 3 gave a limit, no number; the forecaster's own chance of this, stated with the estimate: 15%; middle value at least 6.6-fold (0.82 log units) from the limit.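

In this assay, the carbon with a double bond to nitrogen proves to be a place where a change matters: 2,4-dimethoxyphenyl in place of phenyl gives an at least 7.0-fold higher number from compound 1 to compound 3 (0.84 log units; beyond the scatter). On these data alone, compound 3 reads > 200000 nM, which is a limit of the assay and not a number, so the full size of this step stays unknown. Changes at two different places of compound 1 have now each ended at the same limit, leaving compound 1 as the only compound with a plain number: the limit of > 200000 nM in this assay, at which 2 of the 3 values shown sit.

The compounds shown leave open whether a single methoxy group on the phenyl ring would raise the number as well. Also open, as far as these compounds go, is whether a fluorine atom or a hydroxyl group on that ring would keep the number of compound 1, raise it or lower it.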